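Cyano for Methylsulfonyl: Expected Cytotoxicity of Compound 4

The compounds below may be only part of what the source reports. "The series", "measured", "known", "first", "only" and "open" are said of these compounds alone.

The measured compounds and their values:

Compound 1, `CC(=O)N1CCC(C(=O)N(CCCN2CCN(Cc3ccc(C(F)(F)F)cc3)CC2)c2ccc(C)c(Cl)c2)CC1`: in an ADME assay (Homo sapiens) for cytotoxicity (on this read-out higher numbers stand for lower toxicity in this test and lower numbers for higher toxicity in this test), compound 1 gives 30500 nM.

Compound 2, `CC(=O)N1CCC(C(=O)N(CCCN2CCN(Cc3ccncc3)CC2)c2ccc(C)c(Cl)c2)CC1`: in this assay compound 2 gives > 56700 nM, which is a limit of the assay rather than a number.

Compound 3, `CC(=O)N1CCC(C(=O)N(CCCN2CCN(Cc3ccc(S(C)(=O)=O)cc3)CC2)c2ccc(C)c(Cl)c2)CC1`: in this assay compound 3 gives > 49200 nM, likewise only a limit.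

Compound 3 thus stands at an assay limit, and compound 2 stands at another such limit, so the step between them cannot be read: a step that the two limits leave unreadable from compound 2 to compound 3. The two steps with a stated floor, an at least 1.8-fold higher number from compound 1 to compound 2 (0.26 log units; that floor lies within the scatter) and an at least 1.6-fold higher number from compound 1 to compound 3 (0.20 log units; that floor lies within the scatter), both have floors that lie within the usual scatter, so no movement beyond the scatter is visible in this series.

Compound 4, `CC(=O)N1CCC(C(=O)N(CCCN2CCN(Cc3ccc(C#N)cc3)CC2)c2ccc(C)c(Cl)c2)CC1`, differs from compound 3 by cyano in place of methylsulfonyl on an aromatic carbon. Within the data shown here, the steps that bear on this change are those that alter the group on a saturated chain carbon bound to an amine nitrogen in a ring, namely an at least 1.6-fold higher number from compound 1 to compound 3 (0.20 log units; that floor lies within the scatter) and an at least 1.8-fold higher number from compound 1 to compound 2 (0.26 log units; that floor lies within the scatter), and neither shows a shift beyond the scatter. Among the measured compounds shown here, no step of readable size in this assay is therefore expected for compound 4, and the expected step of an at least 1.0-fold lower number from compound 3 to compound 4 (0.03 log units; that floor lies within the scatter) is small. Compound 4 is estimated at 45000 nM, within a range from 20000 nM to 100000 nM.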

Compound 4, half-maximal cytotoxic concentration: > 100000 nM
Compound 4: a limit, no number; the forecaster's own chance of this, stated with the estimate: 55%; middle value at least 2.2-fold (0.34 log units) away from the limit.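

In this assay compound 4 gives > 100000 nM, which is a limit of the assay and not a number. Cyano in place of trifluoromethyl on this aromatic carbon, para to a large group, gives an at least 3.2-fold higher number from compound 1 to compound 4 (0.51 log units; beyond the scatter), so a change in this part of the molecule now shows a step beyond the scatter, whereas the earlier steps with a stated floor stayed within it. The swap of methylsulfonyl for cyano itself still has no size, and neither the step to compound 4 from compound 3 nor the step to compound 4 from compound 2 can be read, because both ends of each step are limits, among them this one: the limit of > 100000 nM in this assay, at which 1 of the 4 values shown sits.

On these data alone, only compound 1 carries an actual number in this assay, so the order among compound 2, compound 3 and compound 4 stays open. Whether an amine or a carboxylic acid on this same aromatic carbon would give a number or another limit is open as well.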